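The source may hold more compounds than are shown below. What is called first, only, known or untested is meant among the compounds shown, and "the series" means these compounds.

In a functional assay on MT4 cells (Homo sapiens) for cytotoxicity (a lower number here means that less compound is tolerated, a higher number that more compound is tolerated), compound 1 (`CC(C)CSc1nc(O)cc(C(C)c2c(F)cccc2F)n1`) gives > 200000 nM. That figure is a limit of the assay and not a number. Compound 2 (`CC(c1cc(O)nc(SC2CCCCC2)n1)c1c(F)cccc1F`) gives > 200000 nM, which is again a limit. All the evidence so far is therefore (the limit of > 200000 nM in this assay, at which 2 of the 2 values shown sit). For the measured compounds named here, the only measured step is a step that the two limits leave unreadable from compound 1 to compound 2. It swaps the group on sulfur and offers no size to carry forward.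

Compound 3 (`Cc1c(O)nc(SCC(C)C)nc1C(C)c1c(F)cccc1F`) keeps the isobutylsulfanyl group of compound 1 and differs elsewhere: methyl in place of hydrogen on an aromatic carbon. Going by the values given here, no measured step touches this place, so the expectation rests on two things: the change is a single methyl, and compound 1 gives > 200000 nM, a limit. Compound 3 is expected to remain well tolerated in this assay. The expected size of the change, a number no higher from compound 1 to compound 3 (the limit leaves the size open), is nothing beyond the usual scatter. For compound 3 the estimated value is 200000 nM, with an expected range from 90000 nM to 300000 nM. The assay may well report only a limit again.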

Compound 3, half-maximal cytotoxic concentration: > 200000 nM
Compound 3 was reported as a limit; the forecaster's own chance of this, stated with the estimate: 80%; the middle value lies on the limit itself.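

For the compounds shown here, compound 1 and compound 3 both sit at a limit in this assay, so the methyl in place of hydrogen gives no step that can be read. The concentration at which compound 1, compound 2 or compound 3 would become cytotoxic stays open, as does whether either change shifts it, and the evidence remains only this: the limit of > 200000 nM in this assay, at which 3 of the 3 values shown sit.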